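Fourth Analogue Tested Where Three Showed Nothing

The compounds below may be only part of what the source reports. "The series", "measured", "known", "first", "only" and "open" are said of these compounds alone.

Compound 1, `CC(C)(C)c1csc(N)c1C(=O)c1ccc(Cl)cc1`, gives 1% in an assay on CHO cells for displacement of a labelled ligand from adenosine receptor A3 (Homo sapiens), read by scintillation counting, tested at 10 uM; a lower number here means less inhibition, a higher number more inhibition at the concentration tested (going by the name of the read-out).
Compound 2, `Nc1sc(-c2ccccc2)c(-c2ccccc2)c1C(=O)c1ccc(Cl)cc1`, gives 1% in this assay.
Compound 3, `CC(C)(C)Cc1c(-c2cccnc2)sc(N)c1C(=O)c1ccc(Cl)cc1`, gives 1% in this assay.

The three measured compounds share a core and differ in the groups attached to it, yet in this assay they are level at the digits shown. Compound 3 sits with compound 1 and compound 2, with no change at the digits shown; the nearest value is that of compound 1, the furthest that of compound 2, and both gaps lie within the scatter. Nothing among these three separates one compound from another.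

The next compound, compound 4, `CC(C)(C)Cc1c(-c2c(F)cccc2F)sc(N)c1C(=O)c1ccc(Cl)cc1`, is derived from compound 3 by one change: 2,6-difluorophenyl in place of pyridin-3-yl on an aromatic carbon.

Going by the values given here, no step between measured compounds is known, so there is no measured guide to how this exchange acts. Given that every compound so far sits at the same low level, the expectation for the step from compound 3 to compound 4 is none beyond the scatter, estimated as a number 2 percentage points higher from compound 3 to compound 4 (within the scatter). Compound 4 is therefore expected to give about 3% in this assay, with a range from -8% to 15%.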

Compound 4, a percentage reported as inhibition, at one concentration (the size of the read-out at that concentration, not a potency): 1%
For compound 4 the middle estimate is 2 percentage points above the measured one; low and high end bracket the measured number.
By their numbers in this assay, from the lowest: compounds 1, 2, 3 and 4 (each within the scatter of the next).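

In this assay, putting 2,6-difluorophenyl in place of pyridin-3-yl on the aromatic carbon next to the ring sulfur gives no change at the digits printed from compound 3 to compound 4 (within the scatter). Going by these compounds alone, this is the first step where only one place differs, so it adds something the earlier comparisons could not: with the neopentyl group and the rest of the molecule held constant, replacing a ring that contains nitrogen and carries a hydrogen-bond acceptor with a carbon-only ring bearing two fluorines leaves the reading where it was. No measurement shown here explains this result, and with readings this low the step shows only that this exchange does not raise inhibition at the concentration tested.

On these data alone, it remains open whether any group at this position can raise the reading, for example a carboxylic acid, a piperidine ring or a longer alkyl chain in place of the aromatic ring. Also open, as far as these compounds go, is whether a change at this position would matter once another part of the molecule gives a measurable level of inhibition, since a series sitting this low has little room to reveal a further loss.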